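Chloro on the Benzoyl Ring of Compound 1

The compounds below may be only part of what the source reports. "The series", "measured", "known", "first", "only" and "open" are said of these compounds alone.

Measured so far:
compound 1, `COc1cc(-c2nnc3n2NC(c2cccs2)C(C(=O)c2ccccc2)S3)cc(OC)c1OC`: > 100000 nM
compound 2, `COc1cc(-c2nnc3n2NC(c2ccco2)C(C(=O)c2ccccc2)S3)cc(OC)c1OC`: 90900 nM
compound 3, `COc1cc(-c2nnc3n2NC(c2ccco2)C(C(=O)c2ccc(F)c(F)c2)S3)cc(OC)c1OC`: 52400 nM

In a functional assay on HepG2 cells (Homo sapiens) for cytotoxicity, read by MTT assay, with a stated time of 48 h (on this read-out lower numbers stand for stronger inhibition and higher numbers for weaker inhibition), compound 1 gives only a limit, (the limit of > 100000 nM in this assay, at which 1 of the 3 values shown sits), so its own number is not known. Compound 4, `COc1cc(-c2nnc3n2NC(c2cccs2)C(C(=O)c2ccc(Cl)cc2)S3)cc(OC)c1OC`, differs from it by chloro in place of hydrogen on an aromatic carbon. The step that bears on this change is the one in which a halogen enters the benzoyl ring: a 1.7-fold lower number from compound 2 to compound 3 (0.24 log units; within the scatter). The other step, an at least 1.1-fold lower number from compound 1 to compound 2 (0.04 log units; that floor lies within the scatter), changes a different ring and stays at the limit. On this basis compound 4 is expected to show an at least 1.1-fold lower number from compound 1 to compound 4 (0.07 log units; that floor lies within the scatter), a step not beyond the scatter, if any. Compound 4 is therefore estimated at 85000 nM, in a range from 40000 nM to 200000 nM.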

Compound 4, half-maximal inhibitory concentration: 13200 nM
The estimate for compound 4 lay 6.4-fold (0.81 log units) above the measured number, and the stated range ends above it.
By their numbers in this assay, from the lowest: compound 4; then compounds 3 and 2 (each within the scatter of the next). At a limit, above all of these: compound 1.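

In this assay, phenyl to 4-chlorophenyl gives an at least 7.5-fold lower number from compound 1 to compound 4 (0.87 log units; beyond the scatter), the only step shown that lies beyond the scatter. The other halogen change on this ring, on the furan-2-yl compounds, gives a 1.7-fold lower number from compound 2 to compound 3 (0.24 log units; within the scatter), so chloro here registers where 3,4-difluorophenyl did not. This step remains a floor, because compound 1 has no number of its own: the limit of > 100000 nM in this assay, at which 1 of the 4 values shown sits.

The compounds shown leave open what a methoxy group or an amine would give at this place. They also leave open whether chloro has the same effect on compound 2.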